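The source may hold more compounds than are shown below. What is called first, only, known or untested is meant among the compounds shown, and "the series" means these compounds.

Measured so far in a functional assay on UACC-62 cells (Homo sapiens) for cytotoxicity, read by sulforhodamine B assay, with a stated time of 48 h, tested at 10 uM; on this read-out higher numbers stand for a weaker effect at the one concentration tested and lower numbers for a stronger effect:
compound 1 `COc1cc(-c2cc(/C=C/C(=O)c3ccc(N)cc3)[nH]n2)cc(OC)c1OC` — -69%
compound 2 `COc1ccc(-c2cc(/C=C/C(=O)c3ccc(OC)c(OC)c3)[nH]n2)cc1` — -77%
compound 3 `COc1cc(-c2cc(/C=C/C(=O)c3ccc(Cl)c(Cl)c3)[nH]n2)cc(OC)c1OC` — 63%

Going by the values given here, compound 1 stands second highest of the three numbers; compound 2 lies within the scatter of it, while compound 3 lies far above, the step of a number 132 percentage points higher from compound 1 to compound 3 (beyond the scatter) being the only single-point change measured, and it concerns the aryl on the carbonyl carbon, not the ring altered here.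

Compound 4 `COc1ccc(-c2cc(/C=C/C(=O)c3ccc(N)cc3)[nH]n2)cc1OC` differs from compound 1 by hydrogen in place of methoxy on an aromatic carbon on the six-membered aromatic ring of carbon only. Among the compounds with values here, no measured step touches this ring; compounds 1 and 2, which differ in more than one place, show values within the scatter of each other. The step of a number 7 percentage points higher from compound 1 to compound 4 (within the scatter) is therefore expected to stay within the scatter. Compound 4 is estimated at -62%, range -95% to -20%.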

Compound 4, a percentage reported as activity, at one concentration (the size of the read-out at that concentration, not a potency): 3%
For compound 4 the middle estimate is 65 percentage points below the measured one; measured number above the stated range.
By their numbers in this assay, from the lowest: compounds 2 and 1 (each within the scatter of the next); then compound 4; then compound 3.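

Hydrogen in place of methoxy in this assay gives a number 72 percentage points higher from compound 1 to compound 4 (beyond the scatter) and so shows that the methoxy on this aromatic carbon, ortho to a methoxy group and meta to a large group, counts towards the effect at the one concentration tested. The ring carrying it thus joins the aryl on the carbonyl carbon as a second place of large change in the series. Nothing at hand bears on the reason for this step. Open, from the compounds shown here alone, is whether hydroxy, ethoxy or fluorine on this carbon would hold the effect of compound 1, and whether the same change would act alike alongside the 3,4-dichlorophenyl of compound 3.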